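The source may hold more compounds than are shown below. What is called first, only, known or untested is meant among the compounds shown, and "the series" means these compounds.

Working notes on the series. Compound 1 `O=C(/C=C/c1ccc(OCc2cn(Cc3ccccc3F)nn2)cc1)c1ccc(Br)cc1` holds the highest of the two numbers recorded in a functional assay on HepG2 cells (Homo sapiens) for inhibition, read by MTT assay, with a stated time of 48 h, tested at 10 uM; on this read-out lower numbers stand for less inhibition of growth and higher numbers for more inhibition of growth at the one concentration tested; in this assay compound 1 gives 29%, and compound 2 `O=C(/C=C/c1ccc(OCc2cn(Cc3ccc(F)cc3)nn2)cc1)c1ccc(Br)cc1` gives 22%, so that the step of a number 7 percentage points lower from compound 1 to compound 2 (within the scatter) does not separate the two. Compound 3 `COc1ccc(C(=O)/C=C/c2ccc(OCc3cn(Cc4ccccc4F)nn3)cc2)cc1` is not yet measured. It differs from compound 1 by methoxy in place of bromo on an aromatic carbon. Going by the values given here, the single measured step, a number 7 percentage points lower from compound 1 to compound 2 (within the scatter), concerns the fluorophenyl on the saturated chain carbon bound to the aromatic nitrogen, a different place in the molecule, and therefore gives no direct guide to an exchange on the (4-bromophenyl)carbonyl end. Among the compounds with values here, no pair of compounds shows what methoxy in place of bromo does here. With nothing to point either way, the step from compound 1 to compound 3 is expected to be small, a number 4 percentage points lower from compound 1 to compound 3 (within the scatter), within the scatter. Compound 3 is therefore estimated at 25%, with a range from 10% to 45%.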

Compound 3, percent growth inhibition at one concentration: 33%
Estimate against measurement, compound 3: 8 percentage points below; the measured number falls inside the stated range.
By their numbers in this assay, from the lowest: compounds 2, 1 and 3 (each within the scatter of the next, the first and the last beyond it).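

Methoxy in place of bromo, on an aromatic carbon para to a large group, gives a number 4 percentage points higher from compound 1 to compound 3 (within the scatter) in this assay, the first reading of any change at this position. In this single pair, the 4-bromophenyl and 4-methoxyphenyl groups are not told apart, although one heavy atom leaves, two enter, and the entering methoxy brings one hydrogen-bond acceptor where bromo has none. No measurement on hand bears on why this exchange reads as it does.

Still open, from the compounds shown here alone, is how an amine or a carboxylic acid would read at this same position on the core of compound 1. Also open, going by these compounds, is whether methoxy in place of bromo reads the same when the 4-fluorophenyl group of compound 2 replaces the 2-fluorophenyl group.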